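A few compounds are considered here, and "the series" means these few. Any claim that something is new, unique, unknown or untested is made for them only; others in the source may bear on it.

Measured so far:
- compound 1, `CO[C@@]12CCN(C)C[C@H]1[C@H](c1ccc(Br)cc1)C(C#N)=C(N)O2`, in a functional assay on trachea (Cavia porcellus) (on this read-out lower numbers stand for stronger inhibition and higher numbers for weaker inhibition), compound 1 gives 7900 nM
- compound 2, `CO[C@@]12CCN(C)C[C@H]1[C@H](c1ccc(Cl)cc1)C(C#N)=C(N)O2`, in this assay compound 2 gives 10500 nM
- compound 3, `CO[C@@]12CCN(Cc3ccccc3)C[C@H]1[C@H](c1ccc(Cl)cc1)C(C#N)=C(N)O2`, in this assay compound 3 gives 18500 nM

Compound 2 stands second highest of these three numbers. Its nearest neighbour is compound 1, with a 1.3-fold higher number from compound 1 to compound 2 (0.12 log units; within the scatter), and its furthest is compound 3, with a 1.8-fold higher number from compound 2 to compound 3 (0.25 log units; within the scatter); both steps lie within the scatter, so nothing here separates the three compounds with confidence.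

Compound 4, `CO[C@@]12CCN(C)C[C@H]1[C@H](c1ccc(F)cc1)C(C#N)=C(N)O2`, differs from compound 2 by fluoro in place of chloro on an aromatic carbon. The measured step that bears on this change is the earlier halogen swap on the same ring, from compound 1 to compound 2, which was a 1.3-fold higher number from compound 1 to compound 2 (0.12 log units; within the scatter) and within the scatter. Exchanging one halogen for another at that aromatic carbon thus left the number essentially unchanged. The step from compound 2 to compound 4 is therefore expected to be small as well, at most a slight drift toward a higher number, a 1.1-fold higher number from compound 2 to compound 4 (0.06 log units; within the scatter). For compound 4 the expected value in this assay is 12000 nM, with a range from 5000 nM to 30000 nM.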

Compound 4, half-maximal inhibitory concentration: 19400 nM
The estimate for compound 4 lay 1.6-fold (0.21 log units) below the measured number; low and high end bracket the measured number.
By their numbers in this assay, from the lowest: compounds 1, 2, 3 and 4 (each within the scatter of the next, the first and the last beyond it).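

Swapping chloro for fluoro on this aromatic carbon gives a step that stays within the scatter in this assay (a 1.8-fold higher number from compound 2 to compound 4 (0.27 log units; within the scatter)), so this pair alone cannot be told apart. Comparing fluoro directly with bromo at the same carbon gives the first step in this set to pass the scatter, although only modestly (a 2.5-fold higher number from compound 1 to compound 4 (0.39 log units; beyond the scatter)), so the choice of halogen here has a small but readable link to the number. Nothing shown gives a reason for this difference.

The compounds shown leave open whether an iodo or methoxy group, or plain hydrogen, at this carbon would stay close to these numbers or move well away from them. As far as these compounds go, it also remains open whether the gap between bromo and fluoro would persist in the setting of compound 3, which carries the added phenyl.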